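The source may hold more compounds than are shown below. What is called first, only, known or untested is meant among the compounds shown, and "the series" means these compounds.

Working notes on the series.

Compound 1 `COc1cc2c(Oc3ccc(NC(=O)c4nn(-c5ccccc5)c(=O)cc4C)cc3F)ccnc2cc1OCCCN1CCCC1` is the reference point. In a functional assay on A549 cells (Homo sapiens) for inhibition, read by MTT assay, with a stated time of 72 h (a higher number here means a weaker inhibitor, a lower number a stronger inhibitor), compound 1 gives 370 nM. Compound 2 `COc1cc2c(Oc3ccc(NC(=O)c4nn(-c5ccccc5)c(=O)cc4C)cc3F)ccnc2cc1OCCCN1CCCCC1` keeps the whole core of compound 1 and differs only at the end of the chain; the counted difference is piperidin-1-yl in place of pyrrolidin-1-yl on a saturated chain carbon, three bonds along the chain from an oxygen on an aromatic ring. In this assay compound 2 gives 150 nM, so the step is a 2.5-fold lower number from compound 1 to compound 2 (0.39 log units; beyond the scatter).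

Compound 3 `COc1ccc(-n2nc(C(=O)Nc3ccc(Oc4ccnc5cc(OCCCN6CCCC6)c(OC)cc45)c(F)c3)c(C)cc2=O)cc1` differs from compound 1 by methoxy in place of hydrogen on an aromatic carbon. In this assay compound 3 gives 2770 nM, and the step is a 7.5-fold higher number from compound 1 to compound 3 (0.87 log units; beyond the scatter); compound 3 has the highest number of the three measured compounds, with the two steps to the others both beyond the scatter.

Compound 4 `COc1ccc(-n2nc(C(=O)Nc3ccc(Oc4ccnc5cc(OCCCN6CCCCC6)c(OC)cc45)c(F)c3)c(C)cc2=O)cc1` has not yet been measured in this assay. It differs from compound 3 by piperidin-1-yl in place of pyrrolidin-1-yl on a saturated chain carbon, three bonds along the chain from an oxygen on an aromatic ring. The place of this change is described in the same words as for the change from compound 1 to compound 2, so it is the same change applied to the core of compound 3 rather than to the core of compound 1. Within the data shown here, only one measured instance of the change exists, so the expectation rests on it alone: because the earlier step was a 2.5-fold lower number from compound 1 to compound 2 (0.39 log units; beyond the scatter), a step of about the same size, a 2.5-fold lower number from compound 3 to compound 4 (0.40 log units; beyond the scatter), is expected from compound 3 to compound 4. On that basis compound 4 is estimated at 1100 nM, with an expected range from 450 nM to 2800 nM.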

Compound 4, half-maximal inhibitory concentration: 1500 nM
Estimate against measurement, compound 4: 1.4-fold (0.13 log units) below; low and high end bracket the measured number.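

Working notes, continued. In this assay, piperidin-1-yl in place of pyrrolidin-1-yl gives a 1.8-fold lower number from compound 3 to compound 4 (0.27 log units; within the scatter), and this step matches the one seen on the core of compound 1: the same change on two cores in this assay, a 2.5-fold lower number (0.39 log units; beyond the scatter) from compound 1 to compound 2 and a 1.8-fold lower number (0.27 log units; within the scatter) from compound 3 to compound 4, 1.3-fold (0.13 log units) apart, within the scatter of two such steps. The methoxy change, read on the piperidin-1-yl compounds, gives a 10-fold higher number from compound 2 to compound 4 (1.00 log units; beyond the scatter), and it also carries over from one member of the series to the other: the same change on two cores in this assay, a 7.5-fold higher number (0.87 log units; beyond the scatter) from compound 1 to compound 3 and a 10-fold higher number (1.00 log units; beyond the scatter) from compound 2 to compound 4, 1.3-fold (0.13 log units) apart, within the scatter of two such steps. Each change therefore gives steps that agree across these two cores, with no sign in compounds 1 to 4 that one change alters the size of the other, but this rests on a single pair of steps per change in one assay, the step to compound 4 from compound 3 does not by itself establish a difference, and nothing here explains why either change has its effect.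

From the compounds shown here alone, it remains open whether the same agreement holds for other amines at the end of the chain, such as morpholin-4-yl or 4-methylpiperazin-1-yl, or for a longer chain carrying the piperidin-1-yl group. Also open, going by these compounds, is whether a group other than methoxy on that aromatic carbon, such as fluoro or chloro, would give a step of similar size on both cores.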